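Changing the Halogen Pattern on a Growth Inhibitor

This account rests on a few compounds, and the source may have more. Where it says the series, first, only, none or still open, it means among the compounds named here.

Of the compounds shown here, three have been tested in a functional assay on MGC-803 cells (Homo sapiens) for antiproliferative activity, read by MTT assay, with a stated time of 72 h; on this read-out higher numbers stand for weaker inhibition and lower numbers for stronger inhibition. Compound 1 `O=C(COc1ccc(C(=O)/C=C/c2ccccc2Br)cc1)N[C@H]1CCOC1=O` gives 12200 nM, the lowest of the two numbers shown. Compound 2 `Cc1ccc(C(C)C)c(OCCSC(=S)N[C@H]2CCOC2=O)c1` gives 43400 nM, a higher number that lies beyond the usual scatter of the assay. For compound 3 `CC(=O)c1ccc(OCCSC(=S)N[C@H]2CCOC2=O)cc1` the assay reports only a limit, > 64000 nM, and not a number. Compound 4 `O=C(COc1ccc(C(=O)/C=C/c2ccc(F)c(F)c2)cc1)N[C@H]1CCOC1=O` is not yet measured; it differs from compound 1 in one place: 3,4-difluorophenyl in place of 2-bromophenyl on a double-bonded chain carbon bound to a double-bonded chain carbon. For the measured compounds named here, no measured step between two compounds that differ in one place is available here, so little guides the size of this change; the expected step from compound 1 to compound 4 is a 1.2-fold lower number from compound 1 to compound 4 (0.09 log units; within the scatter), small and within the scatter. Compound 4 is therefore estimated at 10000 nM, with a range from 4000 nM to 30000 nM.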

Compound 4, half-maximal inhibitory concentration: > 64000 nM
Compound 4: only a limit was reported (the forecaster's own chance of this, stated with the estimate: 8%); middle value at least 6.4-fold (0.80 log units) away from the limit.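

For the compounds shown here, this is the only measured step at a single place: 3,4-difluorophenyl in place of 2-bromophenyl, on a double-bonded chain carbon bound to a double-bonded chain carbon, gives an at least 5.2-fold higher number from compound 1 to compound 4 (0.71 log units; beyond the scatter). The aryl group here is therefore not freely exchangeable, and this swap weakens growth inhibition. The true size of the step is unknown, as the value of compound 4 is a limit and not a number: the limit of > 64000 nM in this assay, at which 2 of the 4 values shown sit.

The swap removes the bromine and adds two fluorines at once, and the compounds shown do not separate these changes. A plain phenyl group at this place could help tell them apart.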